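This account rests on a few compounds, and the source may have more. Where it says the series, first, only, none or still open, it means among the compounds named here.

Of the compounds shown here, three sharing one core have been tested in a functional assay on B16 cells (Mus musculus) for cytotoxicity, read by MTT assay, with a stated time of 48 h; a higher number here means a weaker inhibitor, a lower number a stronger inhibitor: compound 1 `C=C1CCC[C@]2(C)CCC(c3cn(-c4ccc(OC)cc4)nn3)=CC[C@@]12C`, compound 2 `C=C1CCC[C@]2(C)CCC(c3cn(-c4ccc(I)cc4)nn3)=CC[C@@]12C` and compound 3 `C=C1CCC[C@]2(C)CCC(c3cn(-c4ccccc4C(C)=O)nn3)=CC[C@@]12C`. Compound 3 gives 42200 nM, the lowest number of the three, while compound 2 gives 144000 nM and compound 1 gives 209000 nM. The next compound to consider, compound 4 `C=C1CCC[C@]2(C)CCC(c3cn(-c4cccc(OC)c4)nn3)=CC[C@@]12C`, carries 3-methoxyphenyl in place of 2-acetylphenyl on an aromatic nitrogen.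

Within the data shown here, three measured steps bear on this change. Moving to 2-acetylphenyl gave a 5.0-fold lower number from compound 1 to compound 3 (0.69 log units; beyond the scatter) and a 3.4-fold lower number from compound 2 to compound 3 (0.53 log units; beyond the scatter), so giving that group up should run the other way. Iodo in place of methoxy gave a 1.5-fold lower number from compound 1 to compound 2 (0.16 log units; within the scatter), so the two groups on the ring in compounds 1 and 2 separate them little. Among the measured compounds shown here, no measured pair shows what a methoxy group does at the new position, so 3-methoxyphenyl is assumed to behave much like 4-methoxyphenyl, with some allowance for error. A modest rise in this assay is therefore expected, probably somewhat smaller than those two steps. The estimate amounts to an expected 3.1-fold higher number from compound 3 to compound 4 (0.49 log units; beyond the scatter). For compound 4 the estimated value is 130000 nM, with an expected range of 60000 nM to 280000 nM.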

Compound 4, half-maximal inhibitory concentration: 34700 nM
Compound 4: middle estimate off by 3.7-fold (0.57 log units), on the high side; the measured number lies below the stated range.
By their numbers in this assay, from the lowest: compounds 4 and 3 (each within the scatter of the next); then compounds 2 and 1 (each within the scatter of the next).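

In this assay, among these compounds, the step to 3-methoxyphenyl on the aromatic nitrogen gives a 1.2-fold lower number from compound 3 to compound 4 (0.08 log units; within the scatter) and so makes no clear difference, which shows that 2-acetylphenyl is not the only group here that reaches the low end of this series. The new comparison with the same methoxy group named at a different ring position is larger, with a 6.0-fold lower number from compound 1 to compound 4 (0.78 log units; beyond the scatter) as the step from 4-methoxyphenyl, and the step from 4-iodophenyl gives a 4.1-fold lower number from compound 2 to compound 4 (0.62 log units; beyond the scatter) as well. Nothing available here explains these differences.

The compounds shown leave open whether the gain from the 4-substituted rings belongs to the methoxy group itself or would also appear with 3-iodophenyl or 3-acetylphenyl. They also leave open how an amine or a carboxylic acid on this phenyl ring would behave.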